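The compounds below may be only part of what the source reports. "The series", "measured", "known", "first", "only" and "open" are said of these compounds alone.

In a functional assay on DU-145 cells (Homo sapiens) for inhibition, read by trypan blue exclusion, with a stated time of 96 h (on this read-out higher numbers stand for weaker inhibition of growth and lower numbers for stronger inhibition of growth), compound 1 `O=C(/C(=C\c1ccc(Cl)cc1Cl)S(=O)(=O)c1ccc(Br)cc1)c1ccc(Cl)cc1` gives 50000 nM, compound 2 `COc1ccc(/C=C(\C(=O)c2ccc(Br)cc2)S(=O)(=O)c2ccc(Br)cc2)cc1` gives 25000 nM and compound 3 `O=C(/C(=C\c1ccc(Cl)c([N+](=O)[O-])c1)S(=O)(=O)c1ccc(Br)cc1)c1ccc(Br)cc1` gives 10000 nM, the lowest of the three numbers. Compound 4 `O=C(/C(=C\c1ccc(Cl)cc1Cl)S(=O)(=O)c1ccc(Br)cc1)c1ccc(Br)cc1` differs from compound 3 by one change: 2,4-dichlorophenyl in place of 4-chloro-3-nitrophenyl on a double-bonded chain carbon bound to a double-bonded chain carbon. Within the data shown here, the only measured step at this place is a 2.5-fold lower number from compound 2 to compound 3 (0.40 log units; beyond the scatter), which is modest and brought in the group that now leaves. Compound 1, which already carries the 2,4-dichlorophenyl group, gives 50000 nM, though it differs from compound 4 elsewhere. A modest rise in the number is therefore expected in this assay, meaning weaker inhibition of growth. The expected change is a 3.0-fold higher number from compound 3 to compound 4 (0.48 log units; beyond the scatter). For compound 4 the estimate is 30000 nM, with an expected range of 12000 nM to 70000 nM.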

Compound 4, concentration for 50% growth inhibition: 10000 nM
Compound 4: the middle estimate sits 3.0-fold (0.48 log units) above what was measured; the whole stated range lies above it.
By their numbers in this assay, from the lowest: compounds 3 and 4 (each within the scatter of the next); then compounds 2 and 1 (each within the scatter of the next).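

In this assay, among these compounds, 2,4-dichlorophenyl in place of 4-chloro-3-nitrophenyl gives no change at the digits printed from compound 3 to compound 4 (within the scatter), so this position does not separate these two groups, although only one carries a nitro group. Set against 4-methoxyphenyl, 2,4-dichlorophenyl gives a 2.5-fold lower number from compound 2 to compound 4 (0.40 log units; beyond the scatter), while a change elsewhere, bromo in place of chloro on an aromatic carbon, gives a 5.0-fold lower number from compound 1 to compound 4 (0.70 log units; beyond the scatter), so the position is not the only place that moves the number. No supporting measurements are available to explain these steps. As far as these compounds go, whether an amine or a carboxylic acid on this ring would lower the number further remains open.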